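The source may report more compounds than this note shows. Statements on the series, on what has been measured and on what is new or still open speak of the compounds shown alone.

Compound 1 `C=C(Br)C(=O)Nc1cccc(-c2cn3nc(-c4cccs4)sc3n2)c1` gives 410 nM in a functional assay on CCRF-CEM cells (Homo sapiens) for inhibition, read by cell counting, with a stated time of 3 days; on this read-out higher numbers stand for weaker inhibition and lower numbers for stronger inhibition.
Compound 2 `C=C(Br)C(=O)Nc1cccc(-c2cn3nc(CCc4ccccc4)sc3n2)c1` gives 4200 nM.
Compound 3 `C=C(Br)C(=O)Nc1cccc(-c2cn3nc(-c4ccc(Cl)cc4)sc3n2)c1` gives 3200 nM.

Compound 3 stands second highest of the three numbers in this assay: a 1.3-fold lower number from compound 2 to compound 3 (0.12 log units; within the scatter), while a 7.8-fold higher number from compound 1 to compound 3 (0.89 log units; beyond the scatter). Compound 4 `C=C(Br)C(=O)Nc1cccc(-c2cn3nc(Cc4ccc(OC)cc4)sc3n2)c1` differs from compound 3 in one place: 4-methoxybenzyl in place of 4-chlorophenyl on an aromatic carbon. Going by the values given here, no measured step swaps these two groups directly. The nearest guides are the two steps away from compound 1, a 10-fold higher number from compound 1 to compound 2 (1.01 log units; beyond the scatter) and a 7.8-fold higher number from compound 1 to compound 3 (0.89 log units; beyond the scatter), which put a phenethyl group and a 4-chlorophenyl group in much the same region, and the step of a 1.3-fold lower number from compound 2 to compound 3 (0.12 log units; within the scatter), which lies within the scatter. A 4-methoxybenzyl group is therefore expected to land near compound 3, with a step of a 1.1-fold higher number from compound 3 to compound 4 (0.04 log units; within the scatter). Compound 4 is estimated at 3500 nM, in the range 1200 nM to 10000 nM.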

Compound 4, half-maximal inhibitory concentration: 2300 nM
For compound 4 the middle estimate is 1.5-fold (0.18 log units) above the measured one; the range from low to high includes it.
By their numbers in this assay, from the lowest: compound 1; then compounds 4, 3 and 2 (each within the scatter of the next).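

A third replacement for thiophen-2-yl, 4-methoxybenzyl with its hydrogen-bond acceptor, also gives a weaker result in this assay, with a 5.6-fold higher number from compound 1 to compound 4 (0.75 log units; beyond the scatter). The steps of a 1.4-fold lower number from compound 3 to compound 4 (0.14 log units; within the scatter) and a 1.8-fold lower number from compound 2 to compound 4 (0.26 log units; within the scatter) show that phenethyl, 4-chlorophenyl and 4-methoxybenzyl cannot be told apart at this position, while compound 1 remains the strongest of the four. Nothing measured here explains why thiophen-2-yl stands apart. Still open, as far as these compounds go, is whether a furan-2-yl or pyridin-3-yl group would match thiophen-2-yl. So is the effect of an amine or a carboxylic acid at this position.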